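Adding a methyl to a very weak hydroxyurea amide

The source may report more compounds than this note shows. Statements on the series, on what has been measured and on what is new or still open speak of the compounds shown alone.

Compound 1, `CC(C)C(NC(=O)NO)C(=O)NC1CCCCC1`: in a functional assay on MOLT-4 cells (Homo sapiens) for inhibition (on this read-out higher numbers stand for weaker inhibition and lower numbers for stronger inhibition), compound 1 gives > 100000 nM, which is a limit of the assay rather than a number.
Compound 2, `CCC(C)C(NC(=O)NO)C(=O)NC1CCCCC1`: in this assay compound 2 gives 150000 nM.
Compound 3, `CC(C)C(NC(=O)NO)C(=O)NC1CCCC1`: in this assay compound 3 gives > 200000 nM, again a limit of the assay rather than a number.

Compound 3 thus stands only at a limit, and two of the three values shown are limits (the limit of > 100000 nM in this assay, at which 1 of the 3 values shown sits, and (the limit of > 200000 nM in this assay, at which 1 of the 3 values shown sits)). Compound 4, `CCC(C)C(NC(=O)NO)C(=O)NC1CCCC1`, differs from compound 3 by methyl in place of hydrogen on a saturated chain carbon, three bonds along the chain from an amide-type nitrogen and a carbonyl carbon. The same change has been made once already, in a step that the limit leaves unreadable from compound 1 to compound 2, where a limit leaves its size unreadable. The ring change, a step that the two limits leave unreadable from compound 1 to compound 3, is likewise unreadable. Within the data shown here, no measured step therefore gives a usable size for the change ahead, and the only plain number in the set, that of compound 2, sits far up the scale. Compound 4 is therefore expected to stay very weak in this assay, with the step estimated as a number no higher from compound 3 to compound 4 (the limit leaves the size open). The estimate for compound 4 is 200000 nM, in the range 70000 nM to 600000 nM, most likely reported only as a limit.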

Compound 4, half-maximal inhibitory concentration: > 100000 nM
Compound 4: a limit, no number; the forecaster's own chance of this, stated with the estimate: 70%; the middle value lies beyond the limit too.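

In this assay compound 4 gives > 100000 nM, a limit of the assay and not a number. No size can be read for the steps from compound 2 or compound 3 to compound 4. The compounds shown leave open how far methyl in place of hydrogen, or cyclopentyl in place of cyclohexyl, moves inhibition.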